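A few compounds are considered here, and "the series" means these few. Any claim that something is new, unique, unknown or untested is made for them only; others in the source may bear on it.

Of the compounds shown here, three built on one shared core have been tested in a functional assay on CHO cells for antagonist activity at Orexin receptor type 2 (Homo sapiens), read by FLIPR and calcium flux; a lower number here means a stronger inhibitor, a higher number a weaker inhibitor. Compound 1 `CCc1nc(Cl)c2n1CCN([C@@H](C(=O)NC)c1ccccc1)[C@H]2CCc1cccc(C(F)(F)F)c1` gives 10 nM. Compound 2 `CCc1nc(Cl)c2n1CCN([C@@H](C(=O)NC)c1ccccc1)[C@H]2COc1cccc(C(F)(F)F)c1` gives 4 nM, and compound 3 `CCc1nc(Cl)c2n1CCN([C@@H](C(=O)NC)c1ccccc1)[C@H]2CCc1cc(F)c(C(F)(F)F)cc1F` gives 17 nM. Among these three numbers compound 1 stands second highest: the move to compound 2 is a 2.5-fold lower number from compound 1 to compound 2 (0.40 log units; beyond the scatter), a change beyond the scatter, while the move to compound 3 is a 1.7-fold higher number from compound 1 to compound 3 (0.23 log units; within the scatter), which stays within the scatter.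

Compound 4 `CNC(=O)[C@@H](c1ccccc1)N1CCn2c(C3CC3)nc(Cl)c2[C@@H]1CCc1cccc(C(F)(F)F)c1` has not yet been measured. It differs from compound 1 in one place: cyclopropyl in place of ethyl on an aromatic carbon. Both measured steps change the ring that carries the trifluoromethyl group or the link to it, and neither touches the ethyl group on the core, so neither bears directly on this change. They show only that variation elsewhere on the molecule leaves the numbers close to that of compound 1. Among the measured compounds shown here, with no direct precedent, the expected step in this assay is no change at the digits printed from compound 1 to compound 4 (within the scatter), which is to say no change beyond the scatter is anticipated. Compound 4 is therefore estimated at 10 nM, within an expected range from 4 nM to 25 nM.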

Compound 4, half-maximal inhibitory concentration: 7 nM
The estimate for compound 4 lay 1.4-fold (0.15 log units) above the measured number, within the range that was stated.
By their numbers in this assay, from the lowest: compounds 2, 4, 1 and 3 (each within the scatter of the next, the first and the last beyond it).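

Among the compounds shown here, compound 4 gives the first reading at this position, the aromatic carbon between two ring nitrogen atoms, since the earlier steps changed only the trifluoromethyl-bearing end of the molecule. In this assay, placing cyclopropyl where ethyl stood gives a 1.4-fold lower number from compound 1 to compound 4 (0.15 log units; within the scatter), so this pair cannot be told apart in this measurement. At least on the background of compound 1, this position can therefore carry one three-membered non-aromatic ring of carbon only in place of an open ethyl group without a change beyond the scatter, although no measurement here offers an explanation for that result.

The compounds shown leave open how far this position can be varied, for example with a longer chain such as butyl, a cyclohexyl ring, an amine or a carboxylic acid. They also leave open whether cyclopropyl would give a similar reading when paired with the 3-(trifluoromethyl)phenoxy group of compound 2 or the 2,5-difluoro-4-(trifluoromethyl)phenyl group of compound 3.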